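The compounds below may be only part of what the source reports. "The series", "measured", "known", "first", "only" and "open" are said of these compounds alone.

Measured so far in a physicochemical assay for lipophilicity, measured as octanol-water partition; a lower number here means a more polar compound, a higher number a more lipophilic compound:
Compound 1 `CCCCCc1cn(C/C=C(/C)CC/C=C(\C)CCC=C(C)C)nn1`: 7.5
Compound 2 `CCCc1cn(C/C=C(\C)CCC=C(C)C)nn1`: 4.5
Compound 3 `CCCCCc1cn(CC=C(C)C)nn1`: 3.46

Of these three, compound 3 stands lowest, at 3.46. Its nearest neighbour is compound 2 at 4.5 and the furthest is compound 1 at 7.5, both beyond the scatter of repeated measurements.

The unmeasured compound 4 `CCCCCc1cn(C/C=C(\C)CCC=C(C)C)nn1` keeps the pentyl chain of compound 3 and differs at the other chain: 3-methylbut-2-en-1-yl in place of hydrogen on a saturated chain carbon bound to a double-bonded chain carbon. In words, 3-methylbut-2-en-1-yl stands in place of hydrogen on a saturated chain carbon bound to a double-bonded chain carbon.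

Going by the values given here, no two measured compounds differ in only one place, so the size of this step must be inferred. Among the three measured compounds, the number rises with the size of the compound, and none goes against this. Compound 4 is larger than compound 2 at 4.5 and smaller than compound 1 at 7.5, so its number is expected to fall between these two.

An upward step is expected, estimated as a number 2.04 log units higher from compound 3 to compound 4 (beyond the scatter). The estimate for compound 4 is 5.5, with an expected range from 5 to 6.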

Compound 4, partition coefficient: 5.45
Estimate against measurement, compound 4: 0.05 log units above, and the stated range covers the measured number.
By their numbers in this assay, from the lowest: compound 3; then compound 2; then compound 4; then compound 1.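

Placing 3-methylbut-2-en-1-yl in place of hydrogen on a saturated chain carbon bound to a double-bonded chain carbon gives, in this assay, a number 1.99 log units higher from compound 3 to compound 4 (beyond the scatter), which is the first size read for a change at this place alone. At the other chain, ethyl in place of hydrogen on a saturated chain carbon, three bonds along the chain from an aromatic carbon, gives a modest step, a number 0.95 log units higher from compound 2 to compound 4 (beyond the scatter), so adding carbon at either of these two places raises the number. Nothing available explains the size of either step.

Going by these compounds, both changes add only carbon and hydrogen, so the response to an amine or a carboxylic acid on either chain remains open. On these data alone, whether a longer chain at either place would raise the number further also remains open.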